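This account rests on a few compounds, and the source may have more. Where it says the series, first, only, none or still open, it means among the compounds named here.

Measured compounds:
Compound 1, `CCCOC1=C(CCC)C(=O)/C(=C(O)/C=C/c2ccccc2)C(=O)C1(CCC)CCC`: 8.3 uM
Compound 2, `CCCC1=C(OCC(C)C)C(CCC)(CCC)C(=O)/C(=C(O)\C=C\c2ccccc2)C1=O`: 13.4 uM
Compound 3, `CCCC1=C(OC)C(CCC)(CCC)C(=O)/C(=C(O)\C=C\c2ccccc2)C1=O`: "not determined" (no result reported)

These three compounds share one core and differ only in the group on the oxygen attached to the unsaturated carbon. In a functional assay on HepG2 cells (Homo sapiens) for antiproliferative activity, read by sulforhodamine B assay, with a stated time of 3 days (a higher number here means that more compound is needed for the effect, a lower number that less compound is needed), compound 1 gives 8.3 uM, and compound 2 gives 13.4 uM. Within the data shown here, the one step that can be read between measured compounds is a 1.6-fold higher number from compound 1 to compound 2 (0.21 log units; within the scatter), so lengthening or branching the chain on that oxygen has not, on this evidence, moved the number beyond the scatter. Compound 3 carries a methoxy group in the same place, but for compound 3 no number was reported in this assay, so it cannot be placed among the other two.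

The next compound, compound 4, `CCCCOC1=C(CCC)C(=O)/C(=C(O)/C=C/c2ccccc2)C(=O)C1(CCC)CCC`, is reached from compound 3 by the change (propyl in place of hydrogen on a saturated chain carbon bound to an oxygen on an unsaturated carbon). Among the measured compounds shown here, the only measured step that bears on chain length at this oxygen is a 1.6-fold higher number from compound 1 to compound 2 (0.21 log units; within the scatter), which stayed within the scatter. Compound 4 is therefore expected to land near compound 1 and compound 2 in this assay, with no step beyond the scatter anticipated in either direction. Compound 4 is estimated at 10 uM, with a range from 4 uM to 25 uM.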

Compound 4, concentration for half-maximal effect: 8 uM
Compound 4: the middle estimate sits 1.3-fold (0.10 log units) above what was measured, within the range that was stated.
By their numbers in this assay, from the lowest: compounds 4, 1 and 2 (each within the scatter of the next).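

With compound 4 in hand, two changes that the earlier step could not separate at this oxygen can be read apart in this assay: extending the straight chain gives a 1.0-fold lower number from compound 1 to compound 4 (0.02 log units; within the scatter), and replacing isopropyl with propyl on a saturated chain carbon bound to an oxygen on an unsaturated carbon gives a 1.7-fold lower number from compound 2 to compound 4 (0.22 log units; within the scatter), so neither chain extension nor this change in branching moves the number beyond the scatter. Any step from compound 3 cannot be read, so the full change from methoxy to butoxy, for which compound 4 is the end point, has no measured size. The compounds shown offer no evidence to explain these results.

The shown compounds cover only a narrow set of saturated chains on this oxygen, so it remains open how far this lack of a step beyond the scatter extends, whether to a longer chain such as octyl or to a chain ending in an amine or a carboxylic acid. With only one assay shown, it is also open whether the same holds in any other cell line.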